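Methyl on the phenol ring of a salicylanilide nitrile

The compounds below may be only part of what the source reports. "The series", "measured", "known", "first", "only" and "open" are said of these compounds alone.

Compound 1 `Cc1cc(C#N)ccc1NC(=O)c1ccc2cccnc2c1O`: 710 nM
Compound 2 `N#Cc1ccc(NC(=O)c2ccc3cccnc3c2O)cc1`: 370 nM
Compound 3 `N#Cc1ccc(NC(=O)c2ccccc2O)cc1`: 4620 nM

Compound 2 and compound 3 share the amide and the nitrile-bearing ring, but the difference between their two cores is not broken down here. In a functional assay on HL-60 cells (Homo sapiens) for cytotoxicity, read by luminescence and CellTiter-Glo, with a stated time of 3 days (a lower number here means a stronger inhibitor, a higher number a weaker inhibitor), compound 3 gives the highest number of the three, and both steps to it lie beyond the scatter.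

One change recurs. From compound 2 to compound 1 it is methyl in place of hydrogen on an aromatic carbon, and it made a 1.9-fold higher number from compound 2 to compound 1 (0.28 log units; within the scatter). Compound 4 `Cc1ccc(O)c(C(=O)Nc2ccc(C#N)cc2)c1` carries the same kind of change on compound 3: methyl in place of hydrogen on an aromatic carbon. The place differs: in compound 1 the methyl sits ortho to a large group and meta to a cyano group, in compound 4 meta to a large group and para to a hydroxy group.

Resting on compound 3 at 4620 nM and on the small earlier step, a step of a 1.0-fold lower number from compound 3 to compound 4 (0.01 log units; within the scatter) is expected. Compound 4 is estimated at 4500 nM, between 1800 nM and 11000 nM.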

Compound 4, half-maximal inhibitory concentration: 3920 nM
For compound 4 the middle estimate is 1.1-fold (0.06 log units) above the measured one, and the stated range covers the measured number.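

In this assay, methyl in place of hydrogen on an aromatic carbon gives a 1.2-fold lower number from compound 3 to compound 4 (0.07 log units; within the scatter), and this step lies within the scatter. Set beside the earlier step, the two cores do not separate: the same change on two cores in this assay, a 1.9-fold higher number (0.28 log units; within the scatter) from compound 2 to compound 1 and a 1.2-fold lower number (0.07 log units; within the scatter) from compound 3 to compound 4, 2.3-fold (0.35 log units) apart, within the scatter of two such steps. For the compounds shown here, this shows no measurable difference in how the change carries across these two cores, but it does not establish that the change transfers generally: there are only two steps, both small, and the methyl sits in a different place in each.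

On these data alone, it remains open whether methyl at one same place would behave alike on both cores. As far as these compounds go, it also remains open whether an amine or a carboxylic acid in place of that hydrogen would move the number beyond the scatter.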